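The source may report more compounds than this note shows. Statements on the series, on what has been measured and on what is new or still open speak of the compounds shown alone.

Measured in an ADME assay on liver for metabolic stability, with Liver microsome (Homo sapiens) as the target, read by LC-MS, using microsomes, with a stated time of 5 h; a higher number here means faster removal of the compound, a lower number slower removal:
compound 1 `O[C@H](c1ccccn1)[C@]1(c2cc(C(F)(F)F)ccn2)C[C@H](O)C1`: 33.3 mL/min/kg
compound 2 `C[C@]1(O)C[C@@](c2cc(C(F)(F)F)ccn2)([C@H](O)c2ccccn2)C1`: 33.3 mL/min/kg

Compound 2 stands level with compound 1 at the digits shown, within the scatter, and these two readings are all the series offers so far. Next comes compound 3 `O[C@H](c1ccccn1)[C@]1(c2cc(C(F)(F)F)ccn2)C[C@@H](O)C1`, not yet measured in this assay. The change from compound 2 is hydrogen in place of methyl on a saturated ring carbon. Among the compounds with values here, no measured step covers this change, so the expectation rests on two equal readings only: compound 1 at 33.3 mL/min/kg and compound 2 at 33.3 mL/min/kg. No step beyond the scatter is expected in this assay, and no clear direction can be drawn. The estimated step of a 1.1-fold lower number from compound 2 to compound 3 (0.05 log units; within the scatter) is small. For compound 3 the estimated clearance is 30 mL/min/kg, with an expected range of 15 mL/min/kg to 55 mL/min/kg.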

Compound 3, clearance: 33.3 mL/min/kg
Estimate against measurement, compound 3: 1.1-fold (0.05 log units) below; measured number inside the range.
By their numbers in this assay, from the lowest: compounds 1, 2 and 3 (each within the scatter of the next).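

In this assay, within the data shown here, hydrogen can stand in place of methyl on this saturated ring carbon of the four-membered ring with no change at the digits printed from compound 2 to compound 3 (within the scatter), the first reading of this change at this position. Changing the configuration as drawn gives no change at the digits printed from compound 1 to compound 3 (within the scatter), and this pair is a purely stereochemical comparison: the fact that compounds 1 and 3 differ only in the configuration as drawn. Among the three compounds shown, neither the methyl nor the configuration as drawn moves the clearance beyond the scatter.

As far as these compounds go, it remains open whether a larger group on this ring carbon, such as an ethyl or a longer chain, or an amine or a carboxylic acid in place of the hydroxy group, would move the clearance. Also open, from the compounds shown here alone, is what a change to the hydroxy(pyridin-2-yl)methyl group, shared by all three compounds, would do.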